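Ethyl for Phenyl on a Urea: Mouse Microsomal Stability

The compounds below may be only part of what the source reports. "The series", "measured", "known", "first", "only" and "open" are said of these compounds alone.

Measured so far:
compound 1 `O=C(Nc1ccccc1)Nc1ccc(-c2nc(N3CC4CCC(C3)O4)c3cnn(C4CCC5(CC4)OCCO5)c3n2)cc1`: > 0.5 h
compound 2 `CCn1ncc2c(N3CC4CCC(C3)O4)nc(-c3ccc(NC(=O)NC)cc3)nc21`: > 0.5 h
compound 3 `CNC(=O)Nc1ccc(-c2nc(N3CC4CCC(C3)O4)c3cnn([C@H]4CC[C@H](OC)CC4)c3n2)cc1`: > 0.5 h

In an in vitro ADME assay on microsomes (Mus musculus) for metabolic stability (on this read-out higher numbers stand for a longer-lived compound and lower numbers for a shorter-lived compound), compound 1 gives > 0.5 h, which is a limit of the assay rather than a number. Compound 2 likewise gives > 0.5 h, a limit. Compound 3 gives > 0.5 h, again a limit. All three values therefore sit at the limit of > 0.5 h in this assay, at which 3 of the 3 values shown sit. Among the measured compounds shown here, the one single-place step, a step that the two limits leave unreadable from compound 2 to compound 3, cannot be read because both of its ends are limits.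

Compound 4 `CCNC(=O)Nc1ccc(-c2nc(N3CC4CCC(C3)O4)c3cnn(C4CCC5(CC4)OCCO5)c3n2)cc1` differs from compound 1 by ethyl in place of phenyl on an amide-type nitrogen. For the measured compounds named here, no measured step bears on this change, so no step beyond the scatter is expected in either direction, and compound 4 is expected to reach the limit as well. The estimate for compound 4 is 1 h, ranging from 0.5 h to 3 h. This corresponds to an expected step that the limit leaves unreadable from compound 1 to compound 4.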

Compound 4, half-life: 0.45 h
The estimate for compound 4 lay 2.2-fold (0.35 log units) above the measured number; measured number outside the range, below it.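

In this assay, among the compounds shown here, compound 4 gives 0.45 h, the first real number in this set.

The other compounds sit at a limit: the limit of > 0.5 h in this assay, at which 3 of the 4 values shown sit.

Ethyl in place of phenyl on this amide-type nitrogen gives an at least 1.1-fold lower number from compound 1 to compound 4 (0.04 log units; that floor lies within the scatter). From the compounds shown here alone, the change therefore has a lower bound on its size, but the true size remains unknown and may be small.

Going by these compounds, it remains open how far past its limit compound 1 really lies, and what a longer chain such as butyl, or a cyclopropyl ring, would do on this nitrogen.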